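Methoxy for chloro across two related cores

The source may report more compounds than this note shows. Statements on the series, on what has been measured and on what is new or still open speak of the compounds shown alone.

Compound 1 `Cc1[nH]c2ccccc2c1C(c1ccccc1)c1cc2cc(Cl)ccc2o1` and compound 3 `Cc1c(C(c2ccccc2)c2cc3cc(Cl)ccc3o2)[nH]c2ccccc12` are built from the same atoms joined differently; the difference between the two cores is not broken down here. In a functional assay on SiHa cells (Homo sapiens) for cytotoxicity (a lower number here means a stronger inhibitor, a higher number a weaker inhibitor), compound 1 gives 47500 nM, and compound 3 gives 77900 nM, a gap within the scatter. Compound 2 `COc1ccc2oc(C(c3ccccc3)c3c(C)[nH]c4ccccc34)cc2c1` carries the change (methoxy in place of chloro on an aromatic carbon). In this assay compound 2 gives only a limit of the assay, > 100000 nM. The resulting step is open-ended, an at least 2.1-fold higher number from compound 1 to compound 2 (0.32 log units; beyond the scatter), because of the limit of > 100000 nM in this assay, at which 1 of the 3 values shown sits. Compound 4 `COc1ccc2oc(C(c3ccccc3)c3[nH]c4ccccc4c3C)cc2c1` carries the same change on the core of compound 3, (methoxy in place of chloro on an aromatic carbon). For compound 4 a step matching the earlier one is expected, a 2.1-fold higher number from compound 3 to compound 4 (0.33 log units; beyond the scatter), resting on an at least 2.1-fold higher number from compound 1 to compound 2 (0.32 log units; beyond the scatter). Compound 4 is thus expected at 165000 nM, between 80000 nM and 400000 nM, and will quite possibly be reported only as a limit.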

Compound 4, half-maximal inhibitory concentration: > 100000 nM
Compound 4: no number, only a limit; the forecaster's own chance of this, stated with the estimate: 70%; the middle value is on the limit's open side.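

In this assay compound 4 gives only a limit of the assay, > 100000 nM. On the core of compound 3, methoxy in place of chloro gives an at least 1.2-fold higher number from compound 3 to compound 4 (0.10 log units; that floor lies within the scatter), a floor that on its own does not establish a loss on this core. Both methoxy compounds end at a limit, so the results are compatible with the change acting in the same direction on both cores, but its size is fixed on neither and no equal effect is shown: the same change on two cores in this assay, an at least 2.1-fold higher number (0.32 log units; beyond the scatter) from compound 1 to compound 2 and an at least 1.2-fold higher number (0.10 log units; that floor lies within the scatter) from compound 3 to compound 4; the limit leaves it open whether they differ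

On these data alone, how far compound 2 and compound 4 lie beyond the limit remains open. Also open, as far as these compounds go, is how an amine or a carboxylic acid would read on the same aromatic carbon of either core.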